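The source may hold more compounds than are shown below. What is called first, only, known or untested is meant among the compounds shown, and "the series" means these compounds.

Measured so far:
Compound 1 `Fc1ccc2nc(-n3ccnn3)n(C3CC3)c2c1` gives 1060 nM in an assay on cells for inhibition of cytochrome P450 11B2, mitochondrial (Homo sapiens), read by HPLC, with a stated time of 90 min; a lower number here means a stronger inhibitor, a higher number a weaker inhibitor.
Compound 2 `Cc1ncncc1-c1nc2cc(F)c(F)cc2n1C1CC1` gives 17 nM in this assay.

Going by the values given here, compound 2 holds the lowest of the two numbers; compound 1 is its only neighbour, and the gap between the two values lies far beyond the usual scatter. The two structures differ in more than one place, so nothing is said here about which part of the difference carries that gap.

Compound 3 `N#Cc1ncncc1-c1nc2cc(F)c(F)cc2n1C1CC1` is not yet measured. It differs from compound 2 by cyano in place of methyl on an aromatic carbon, on an aromatic carbon of a six-membered aromatic ring with 2 nitrogen, next to the ring nitrogen and ortho to a large group. Among the compounds with values here, no step between measured compounds bears on a change of this kind, so its size and direction remain open. The step of a 1.5-fold higher number from compound 2 to compound 3 (0.17 log units; within the scatter) is expected to be modest, not reliably beyond the scatter. For compound 3 the estimated value in this assay is 25 nM, with a range from 8 nM to 80 nM.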

Compound 3, half-maximal inhibitory concentration: 13 nM
Beside the measured number, compound 3's estimate is 1.9-fold (0.28 log units) above it; low and high end bracket the measured number.
By their numbers in this assay, from the lowest: compounds 3 and 2 (each within the scatter of the next); then compound 1.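

At this position, on an aromatic carbon next to the ring nitrogen and ortho to a large group, cyano in place of methyl gives a 1.3-fold lower number from compound 2 to compound 3 (0.12 log units; within the scatter) in this assay. Going by these compounds alone, this is the first step read at this position, and it does not separate the two groups. The position therefore accepts cyano, with its triple bond and hydrogen-bond acceptor, and the value stays within the scatter of the methyl compound; nothing on hand bears on why the two groups read alike.

On these data alone, whether an amine, a carboxylic acid or a longer chain at this position would stay in the range of compound 2 and compound 3 remains open. Also open, as far as these compounds go, is whether cyano in place of methyl would read the same at any other position on the shared core.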